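A Carboxy Group Replaces the Ester Chain of Compound 1

The source may hold more compounds than are shown below. What is called first, only, known or untested is meant among the compounds shown, and "the series" means these compounds.

Compound 1 `CCOC(=O)CCO/N=C(/c1ccc(OC)c(OC)c1OC)c1cccc2ccccc12`: 19600 nM
Compound 2 `COc1ccc(C(O)(Cc2ccc(F)cc2)c2cccc3ccccc23)c(OC)c1OC`: 5940 nM
Compound 3 `COC(=O)c1ccc(COC(c2ccc(OC)c(OC)c2OC)c2cccc3ccccc23)cc1`: 12000 nM

In a functional assay on A549 cells (Homo sapiens) for inhibition, read by sulforhodamine B assay, with a stated time of 48 h (on this read-out higher numbers stand for weaker inhibition and lower numbers for stronger inhibition), compound 1 gives the highest of the three numbers. The number for compound 3 lies within the usual scatter of it, while compound 2 gives a number that is lower by more than the scatter. Compound 4 `COc1ccc(/C(=N/OCC(=O)O)c2cccc3ccccc23)c(OC)c1OC` differs from compound 1 in a single place: carboxy in place of (ethoxycarbonyl)methyl on a saturated chain carbon bound to an oxygen on an unsaturated carbon. For the measured compounds named here, no pair of measured compounds differing in one place is available to gauge such a change, so the expectation rests on compound 1 alone. A modest step toward a higher number in this assay is expected, a 1.5-fold higher number from compound 1 to compound 4 (0.18 log units; within the scatter). Compound 4 is therefore estimated at 30000 nM, with a range from 10000 nM to 100000 nM.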

Compound 4, half-maximal inhibitory concentration: 17200 nM
For compound 4 the middle estimate is 1.7-fold (0.24 log units) above the measured one, within the range that was stated.
By their numbers in this assay, from the lowest: compound 2; then compounds 3, 4 and 1 (each within the scatter of the next).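

In this assay, carboxy in place of (ethoxycarbonyl)methyl on a saturated chain carbon bound to an oxygen on an unsaturated carbon gives (a 1.1-fold lower number from compound 1 to compound 4 (0.06 log units; within the scatter)). This first step measured at this place shows that the number stays within the scatter when the smaller carboxy, with its hydrogen-bond donor, enters. No measurement explaining this result is available. From the compounds shown here alone, whether an amine or a longer chain ending in carboxy would fit this place equally well remains open. So does whether the same change would hold on another core.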